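The source may hold more compounds than are shown below. What is called first, only, known or untested is meant among the compounds shown, and "the series" means these compounds.

In a functional assay on BXPC-3 cells (Homo sapiens) for antiproliferative activity, read by MTT assay, with a stated time of 24 h; a higher number here means a weaker inhibitor, a lower number a stronger inhibitor:
- compound 1 `CCn1c(C(=O)N[C@@H](C)C(=O)OC)ccc1C(CC)(CC)c1ccc(OCS(=O)(=O)c2ccccc2)c(C)c1`: 17900 nM
- compound 2 `CCn1c(C(=O)N[C@@H](CC(=O)OC)C(=O)OC)ccc1C(CC)(CC)c1ccc(OCS(=O)(=O)c2ccccc2)c(C)c1`: > 50000 nM

Compound 2 stands at a limit of this assay, > 50000 nM, which is not a number. Compound 3 `CCn1c(C(=O)NCCNC(=O)OC(C)(C)C)ccc1C(CC)(CC)c1ccc(OCS(=O)(=O)c2ccccc2)c(C)c1` differs from it in one place: 2-((tert-butoxycarbonyl)amino)ethyl in place of 1,2-bis(methoxycarbonyl)ethyl on an amide-type nitrogen. For the measured compounds named here, the one measured step bearing on this is an at least 2.7-fold higher number from compound 1 to compound 2 (0.44 log units; beyond the scatter), beyond the scatter, and it came with an added methoxycarbonyl. Compound 3 carries no methoxycarbonyl, so a lower number is expected, an estimated at least 2.2-fold lower number from compound 2 to compound 3 (0.35 log units; beyond the scatter). The expected value for compound 3 is 22000 nM, with an estimated range of 8000 nM to 50000 nM.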

Compound 3, half-maximal inhibitory concentration: > 50000 nM
Compound 3: no number, only a limit; the forecaster's own chance of this, stated with the estimate: 25%; middle value at least 2.2-fold (0.35 log units) away from the limit.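

In this assay compound 3 gives > 50000 nM, which is a limit and not a number. On the amide-type nitrogen, the 2-((tert-butoxycarbonyl)amino)ethyl chain gives an at least 2.7-fold higher number from compound 1 to compound 3 (0.44 log units; beyond the scatter), so a rise at this position does not require the added methoxycarbonyl of compound 2. The step between compound 2 and compound 3 cannot be read, because both values are limits: the limit of > 50000 nM in this assay, at which 2 of the 3 values shown sit. Still open, as far as these compounds go, is whether a free primary amine or a carboxylic acid on this chain would lower the number.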